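Methyl to methoxy: notes on compound 3

This account rests on a few compounds, and the source may have more. Where it says the series, first, only, none or still open, it means among the compounds named here.

- compound 1 (`O=C1C=C(NCc2ccccc2)C(=O)c2c1nc1n2[C@H]2OC[C@@H](O)[C@H]2OC1`) gives > 8000 nM (a limit)
- compound 2 (`Cc1ccc(NC2=CC(=O)c3c(nc4n3[C@H]3OC[C@@H](O)[C@H]3OC4)C2=O)cc1`) gives > 4000 nM (a limit)

In a functional assay on ECa-109 cells for inhibition, with ECa-109 cell line (Homo sapiens) as the target, read by sulforhodamine B assay (a lower number here means a stronger inhibitor, a higher number a weaker inhibitor), compound 2 stands only at a limit (> 4000 nM) and gives no number. Compound 3 (`COc1ccc(NC2=CC(=O)c3c(nc4n3[C@H]3OC[C@@H](O)[C@H]3OC4)C2=O)cc1`) carries methoxy in place of methyl on an aromatic carbon, para to a large group (methoxy in place of methyl on an aromatic carbon). Among the compounds with values here, no measured step bears on this change, and no shift beyond the scatter is expected in this assay for it. The estimated step (a step that the limit leaves unreadable from compound 2 to compound 3) is correspondingly small. Compound 3 is estimated at 6000 nM (expected range 2000 nM to 16000 nM), and it may also report only a limit.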

Compound 3, half-maximal inhibitory concentration: 3410 nM
Estimate against measurement, compound 3: 1.8-fold (0.25 log units) above; low and high end bracket the measured number.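

In this assay, compound 3 is the only compound shown that reads as a number rather than a limit, which gives the series a measured reference point. Methoxy in place of methyl on this aromatic carbon gives an at least 1.1-fold lower number from compound 2 to compound 3 (0.06 log units; that floor lies within the scatter), so the change shows no shift beyond the scatter, though a larger one is not excluded. The true size of the step stays unreadable, and the reading rests on a limit: the limit of > 4000 nM in this assay, at which 1 of the 3 values shown sits.

On these data alone, whether a chlorine, a hydroxyl or a dimethylamino group on the same carbon would move the number remains open. So does the effect of methoxy relative to hydrogen there.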